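Ether Side-Chain Variants: Working Notes Toward Compound 4

The source may report more compounds than this note shows. Statements on the series, on what has been measured and on what is new or still open speak of the compounds shown alone.

Measured so far, in a functional assay on MDA-MB-231 cells (Homo sapiens) for antiproliferative activity, read by CCK-8 assay, with a stated time of 48 h; a lower number here means a stronger inhibitor, a higher number a weaker inhibitor:
- compound 1 `O=C(CCCNCCOc1ccc(Oc2c(-c3ccc(F)cc3)sc3cc(O)ccc23)cc1)N1CCC1`: compound 1 gives > 50000 nM, a limit of the assay.
- compound 2 `O=C(/C=C/CNCCOc1ccc(Oc2c(-c3ccc(F)cc3)sc3cc(O)ccc23)cc1)N1CCC1`: compound 2 gives > 50000 nM, a limit of the assay.
- compound 3 `C=C(C)C(=O)N1CC(Oc2ccc(Oc3c(-c4ccc(F)cc4)sc4cc(O)ccc34)cc2)C1`: compound 3 gives > 50000 nM, a limit of the assay.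

Compound 3 therefore stands at the same limit as the other two; no number separates it from them, and none of the three can be called weaker or stronger than another. The steps changing the same position, a step that the two limits leave unreadable from compound 1 to compound 3 and a step that the two limits leave unreadable from compound 2 to compound 3, are unreadable for the same reason, and a step that the two limits leave unreadable from compound 1 to compound 2 is likewise unreadable; this follows from the limit of > 50000 nM in this assay, at which 3 of the 3 values shown sit.

Compound 4 `C=CC(=O)NCCOc1ccc(Oc2c(-c3ccc(F)cc3)sc3cc(O)ccc23)cc1` differs from compound 3 by 2-((vinylcarbonyl)amino)ethyl in place of 1-((1-methylethenyl)carbonyl)azetidin-3-yl on an oxygen on an aromatic ring. Within the data shown here, no measured step gives a readable size for a change at this oxygen, so the expectation rests only on the three limits. The step of an at least 1.1-fold lower number from compound 3 to compound 4 (0.04 log units; that floor lies within the scatter) is expected to be small, most likely leaving compound 4 at the limit as well. For compound 4 the value in this assay is estimated at 45000 nM, with a range from 8000 nM to 50000 nM.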

Compound 4, half-maximal inhibitory concentration: > 50000 nM
Compound 4: no number, only a limit; the forecaster's own chance of this, stated with the estimate: 70%; at least 1.1-fold (0.04 log units) between middle value and limit.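

No step from compound 1, compound 2 or compound 3 to compound 4 can be read, since all four compounds give only a limit: the limit of > 50000 nM in this assay, at which 4 of the 4 values shown sit.

The compounds shown leave open whether any change to the ether side chain gives a measurable number in this assay.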